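Swapping a halogen on the sulfonyl-bearing ring

The source may hold more compounds than are shown below. What is called first, only, known or untested is meant among the compounds shown, and "the series" means these compounds.

Three acylguanidines of a shared core have been measured in a functional assay for inhibition of sodium/hydrogen exchanger (Oryctolagus cuniculus); on this read-out higher numbers stand for weaker inhibition and lower numbers for stronger inhibition. Compound 1 `CCc1cc(Br)c(S(C)(=O)=O)cc1C(=O)N=C(N)N` gives 41 nM. Compound 2 `CS(=O)(=O)c1cc(C(=O)N=C(N)N)ccc1C#N` gives 140 nM, and compound 3 `CS(=O)(=O)c1cc(C(=O)N=C(N)N)ccc1Cl` gives 380 nM, the highest of the three numbers. Among the measured compounds shown here, the single one-change step seen so far, a 2.7-fold higher number from compound 2 to compound 3 (0.43 log units; beyond the scatter), concerns the cyano-to-chloro swap and tells nothing directly about exchanging one halogen for another. Compound 4 `CS(=O)(=O)c1cc(C(=O)N=C(N)N)ccc1Br` differs from compound 3 by bromo in place of chloro on an aromatic carbon. Compound 1 also carries a bromo group, yet it differs from compound 3 in more than one place, so its lower number cannot be credited to the halogen alone. For the measured compounds named here, with no step of the same kind available, an estimate can only lean on the typical closeness of chloro and bromo analogues. The step from compound 3 to compound 4 is therefore expected to be a 1.5-fold lower number from compound 3 to compound 4 (0.18 log units; within the scatter), a change that may not exceed the scatter. Compound 4 is estimated at 250 nM, within a range from 100 nM to 650 nM.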

Compound 4, half-maximal inhibitory concentration: 180 nM
The estimate for compound 4 lay 1.4-fold (0.14 log units) above the measured number, and the stated range covers the measured number.
By their numbers in this assay, from the lowest: compound 1; then compounds 2 and 4 (each within the scatter of the next); then compound 3.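

In this assay, the halogen on this carbon, ortho to a methylsulfonyl group, makes a measurable difference: a 2.1-fold lower number from compound 3 to compound 4 (0.32 log units; beyond the scatter) is a modest change, but it shows that bromo and chloro are not interchangeable here. Bromo and cyano at this position cannot be told apart, with a 1.3-fold higher number from compound 2 to compound 4 (0.11 log units; within the scatter), whereas chloro does separate from cyano, so chloro is the group that differs from the other two. Compound 4 also allows compound 1 to be read as a single change, since both carry bromo: a 4.4-fold higher number from compound 1 to compound 4 (0.64 log units; beyond the scatter) links hydrogen in place of ethyl to a modest rise in the number.

The data offer no explanation for either the halogen step or the ethyl step. As far as these compounds go, how fluoro or an amine would fare on the halogen-bearing carbon remains open, as does the effect of a longer chain such as propyl in place of ethyl.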